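Removing the nitro group from compound 3

The source may hold more compounds than are shown below. What is called first, only, known or untested is meant among the compounds shown, and "the series" means these compounds.

Measured so far in a functional assay on GC-2 cells (Mus musculus) for cytotoxicity, read by MTT assay, with a stated time of 72 h; a lower number here means a stronger inhibitor, a higher number a weaker inhibitor:
- compound 1 `Nc1nc(Nc2ccccc2)sc1C(=O)c1cccnc1` gives 9500 nM
- compound 2 `NC(=O)c1sc(Nc2ccccc2)nc1N` gives > 60000 nM as a limit of the assay
- compound 3 `Nc1nc(Nc2ccc(S(N)(=O)=O)cc2)sc1C(=O)c1ccccc1[N+](=O)[O-]` gives 9000 nM

Going by the values given here, compound 3 at 9000 nM lies within the scatter of compound 1 at 9500 nM and these are the only two true numbers. Compound 4 `Nc1nc(Nc2ccc(S(N)(=O)=O)cc2)sc1C(=O)c1ccccc1` has hydrogen in place of nitro on an aromatic carbon, ortho to a large group, taking 2-nitrophenyl to phenyl (hydrogen in place of nitro on an aromatic carbon). Among the compounds with values here, the only measured step at the carbonyl is an at least 6.3-fold higher number from compound 1 to compound 2 (0.80 log units; beyond the scatter), with amino in place of pyridin-3-yl. That is a different change, so it sets no size here. No step beyond the scatter is expected in this assay, and no direction is favoured. The expected step is a 1.1-fold higher number from compound 3 to compound 4 (0.05 log units; within the scatter). The estimate for compound 4 is 10000 nM, with an expected range of 3500 nM to 30000 nM.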

Compound 4, half-maximal inhibitory concentration: 6100 nM
Beside the measured number, compound 4's estimate is 1.6-fold (0.21 log units) above it; measured number inside the range.
By their numbers in this assay, from the lowest: compounds 4, 3 and 1 (each within the scatter of the next). At a limit, above all of these: compound 2.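

In this assay, going by these compounds alone, hydrogen in place of nitro on an aromatic carbon, ortho to a large group, gives a 1.5-fold lower number from compound 3 to compound 4 (0.17 log units; within the scatter) and is the first step read at this position. The nitro group can therefore be left out with no change beyond the scatter, so 2-nitrophenyl and phenyl cannot be told apart here. Nothing shown gives a cause for this step.

From the compounds shown here alone, whether an amine or a carboxylic acid in place of the nitro group would move the number beyond the scatter stays open. Going by these compounds, whether any group at this position can give a clearly stronger inhibitor also stays open.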